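The source may report more compounds than this note shows. Statements on the series, on what has been measured and on what is new or still open speak of the compounds shown alone.

In an ADME assay on HepG2 cells (Homo sapiens) for cytotoxicity, read by MTT assay, with a stated time of 48 h (a higher number here means that more compound is tolerated, a lower number that less compound is tolerated), three compounds have readings so far. Compound 1 `C#Cc1ccc(-c2noc(NC3CCCCC3)n2)cc1` gives 54.2 ug/mL, and compound 3 `C#CCN(c1nc(-c2ccc(Cl)cc2)no1)C1CCCCC1` gives 41.3 ug/mL, two values that lie within the usual scatter of each other. Compound 2 `CC(=O)OC[C@H]1O[C@H](OC[C@@H](Cn2cc(CN(c3nc(-c4ccc([N+](=O)[O-])cc4)no3)C3CCCCC3)nn2)OC(C)=O)C=C[C@@H]1OC(C)=O` reads > 200 ug/mL, which is a limit of the assay and not a number.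

Compound 4 `C#CCN(c1nc(-c2ccc(Br)cc2)no1)C1CCCCC1` has not yet been measured and differs from compound 3 in one place: bromo in place of chloro on an aromatic carbon. In words, this is bromo in place of chloro on an aromatic carbon, para to a large group. Among the compounds with values here, no two measured compounds differ in just one place, and the data hold no direct guide to this swap. The best anchor is compound 3 at 41.3 ug/mL, and no change beyond the scatter is expected in this assay. The expected step, a 1.0-fold lower number from compound 3 to compound 4 (0.01 log units; within the scatter), is therefore small. For compound 4, the estimated value is 40 ug/mL, with an expected range from 20 ug/mL to 80 ug/mL.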

Compound 4, half-maximal cytotoxic concentration: 102 ug/mL
Compound 4: middle estimate off by 2.6-fold (0.41 log units), on the low side; the whole stated range lies below it.
By their numbers in this assay, from the lowest: compounds 3, 1 and 4 (each within the scatter of the next, the first and the last beyond it). At a limit, above all of these: compound 2.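

In this assay, within the data shown here, the swap of chloro for bromo on an aromatic carbon, para to a large group, gives a 2.5-fold higher number from compound 3 to compound 4 (0.39 log units; beyond the scatter), a modest step but one beyond the usual scatter, and the first comparison here between compounds that differ in one place. The exchange removes one halogen atom and adds another, with no change in ring, hydrogen-bond donors, hydrogen-bond acceptors or net charge, yet it is enough for the cells to tolerate more compound. Nothing in the data explains why this step occurs.

The compounds shown leave open how fluoro, a methoxy group or an amine on this same carbon would read, so a single step cannot establish a trend. On these data alone, it also remains open whether the same swap would give a similar step on a different core.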